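This account rests on a few compounds, and the source may have more. Where it says the series, first, only, none or still open, it means among the compounds named here.

The measured compounds:
compound 1, `CN(C(=O)NC(=O)c1ccc([N+](=O)[O-])cc1)c1nc(C(F)(F)F)c(C(=O)N/N=C/c2ccc([N+](=O)[O-])cc2)s1`, 8.98 ug/mL
compound 2, `CN(C(=O)NC(=O)c1ccc(Cl)c(Cl)c1)c1nc(C(F)(F)F)c(C(=O)N/N=C/c2ccc([N+](=O)[O-])cc2)s1`, 6.44 ug/mL

In a functional assay on A549 cells (Homo sapiens) for inhibition, read by MTT assay, with a stated time of 72 h (a higher number here means a weaker inhibitor, a lower number a stronger inhibitor), compound 1 stands highest of the two numbers; its nearest neighbour is compound 2, and the step of a 1.4-fold lower number from compound 1 to compound 2 (0.14 log units; within the scatter) is within the scatter. Compound 3, `CN(C(=O)NC(=O)c1ccc([N+](=O)[O-])cc1)c1nc(C(F)(F)F)c(C(=O)N/N=C/c2cccc(C(F)(F)F)c2)s1`, has not yet been measured. It differs from compound 1 by 3-(trifluoromethyl)phenyl in place of 4-nitrophenyl on a carbon with a double bond to nitrogen. Within the data shown here, the one measured step, a 1.4-fold lower number from compound 1 to compound 2 (0.14 log units; within the scatter), concerns an exchange on a carbonyl carbon, not on the carbon with a double bond to nitrogen, so it bears on the new change only indirectly; in any case it was small. Nothing else in the data points to a change in either direction, so compound 3 is expected to give a number close to that of compound 1, with a 1.0-fold higher number from compound 1 to compound 3 (0.00 log units; within the scatter) as the estimated step. The estimate for compound 3 in this assay is 9 ug/mL, with a range from 4.5 ug/mL to 18 ug/mL.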

Compound 3, half-maximal inhibitory concentration: 5.42 ug/mL
Estimate against measurement, compound 3: 1.7-fold (0.22 log units) above; the measured number falls inside the stated range.
By their numbers in this assay, from the lowest: compounds 3, 2 and 1 (each within the scatter of the next).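

Among these compounds, this compound gives the first reading at the carbon with a double bond to nitrogen: in this assay the exchange of 4-nitrophenyl for 3-(trifluoromethyl)phenyl there gives a 1.7-fold lower number from compound 1 to compound 3 (0.22 log units; within the scatter) and so stays within the scatter. The 4-nitrophenyl group at this place is therefore not needed for a number in this range, and the same holds for the 4-nitrophenyl on the carbonyl carbon, as compound 2 shows. No measured property bears on why this exchange leaves the number where it is.

Going by these compounds, whether an amine or a carboxylic acid on the phenyl ring at this place would move the number beyond the scatter remains open. Also open, on these data alone, is whether 3-(trifluoromethyl)phenyl at this place would give a similar number alongside the 3,4-dichlorophenyl of compound 2.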